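Benzoyl in place of phenyl: a second step

The compounds below may be only part of what the source reports. "The series", "measured", "known", "first", "only" and "open" are said of these compounds alone.

Compound 1 `Cc1nnc(SCc2ccccc2)n1N1C(=O)c2ccccc2C1=O` is the starting point of the set. In a functional assay on MKN-45 cells (Homo sapiens) for cytotoxicity, read by MTT assay, with a stated time of 48 h (on this read-out higher numbers stand for weaker inhibition and lower numbers for stronger inhibition), compound 1 gives > 200000 nM, which is a limit of the assay and not a number. Compound 2 `Cc1nnc(SCC(=O)c2ccccc2)n1N1C(=O)c2ccccc2C1=O` carries the change (benzoyl in place of phenyl on a saturated chain carbon bound to a sulfur). In this assay compound 2 gives > 200000 nM, again a limit. The step that the two limits leave unreadable from compound 1 to compound 2 cannot be sized because the limit of > 200000 nM in this assay, at which 3 of the 3 values shown sit, covers both ends of it. Compound 3 `COc1cc(-c2nnc(SCc3ccccc3)n2N2C(=O)c3ccccc3C2=O)cc(OC)c1OC` differs from compound 1 by 3,4,5-trimethoxyphenyl in place of methyl on an aromatic carbon. In this assay compound 3 gives > 200000 nM, also a limit. The step that the two limits leave unreadable from compound 1 to compound 3 is likewise unreadable.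

Compound 4 `COc1cc(-c2nnc(SCC(=O)c3ccccc3)n2N2C(=O)c3ccccc3C2=O)cc(OC)c1OC` has not yet been measured. It differs from compound 3 by benzoyl in place of phenyl on a saturated chain carbon bound to a sulfur, the same change as from compound 1 to compound 2, at a place described in the same words. With no readable step anywhere in the set and all three values sitting at the limit, compound 4 is expected to sit there as well, so the step that the limit leaves unreadable from compound 3 to compound 4 is estimated as flat. Compound 4 is estimated at 250000 nM, between 100000 nM and 1000000 nM.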

Compound 4, half-maximal inhibitory concentration: > 200000 nM
Compound 4 gave a limit, no number; the forecaster's own chance of this, stated with the estimate: 85%; the middle value does not contradict the limit.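

In this assay compound 4 gives > 200000 nM, a limit and not a number. No step can be read from compound 3 to compound 4 or from compound 2 to compound 4, because both ends of each pair sit at the same limit: the limit of > 200000 nM in this assay, at which 4 of the 4 values shown sit.

The compounds shown leave open what size either change has in this assay.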